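This account rests on a few compounds, and the source may have more. Where it says the series, first, only, none or still open, it means among the compounds named here.

In an ADME assay on microsomes from liver (Homo sapiens) for metabolic stability, read by LC-MS, with a stated time of 10 min, tested at 0.5 uM (a higher number here means that more of the compound is left, a lower number that less of the compound is left), compound 2 `NC(=O)N1CCN(CCCN(C[C@H]2Cc3ccccc3CN2)[C@H]2CCCc3cccnc32)CC1` stands highest of the two measured compounds at 79%, while compound 1 `CCN1CCN(CCCN(C[C@H]2Cc3ccccc3CN2)[C@H]2CCCc3cccnc32)CC1` gives 59%. The next structure, compound 3 `c1ccc2c(c1)CN[C@@H](CN(CCCN1CCN(C3CC3)CC1)[C@H]1CCCc3cccnc31)C2`, has cyclopropyl in place of carbamoyl on an amine nitrogen in a ring. Among the compounds with values here, only one measured step bears on this change: a number 20 percentage points higher from compound 1 to compound 2 (beyond the scatter), with carbamoyl in place of ethyl on an amine nitrogen in a ring. Within the data shown here, compound 3 removes that same carbamoyl, but it carries cyclopropyl rather than ethyl, and no cyclopropyl compound has yet been measured. A downward step of similar size is therefore expected, estimated as a number 17 percentage points lower from compound 2 to compound 3 (beyond the scatter). For compound 3 the expected value is 62%, with an estimated range from 48% to 76%.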

Compound 3, percent of the compound remaining: 21%
Estimate against measurement, compound 3: 41 percentage points above, outside the stated range (below it).
By their numbers in this assay, from the lowest: compound 3; then compound 1; then compound 2.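

In this assay, the group on this amine nitrogen in a ring moved the read-out far more than the earlier pair had shown: replacing carbamoyl with cyclopropyl gave a number 58 percentage points lower from compound 2 to compound 3 (beyond the scatter) in a single change. The fall does not reflect the loss of carbamoyl alone, since replacing ethyl with cyclopropyl still gave a number 38 percentage points lower from compound 1 to compound 3 (beyond the scatter) even though neither group is carbamoyl. Across these three compounds, ethyl and cyclopropyl are therefore not interchangeable at this position, and nothing available gives a cause for the difference.

Going by these compounds, whether the low number belongs to the three-membered ring itself or extends to a cyclobutyl group remains open. On these data alone, it is also open where an acetyl or isopropyl group on the same nitrogen would fall relative to these three compounds.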